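This account rests on a few compounds, and the source may have more. Where it says the series, first, only, none or still open, it means among the compounds named here.

Of the compounds shown here, three sharing one core have been tested in an assay on HEK293 cells for agonist activity at transient receptor potential cation channel subfamily M member 8 (Homo sapiens), read by fluorescence and calcium flux, with a stated time of 15 min; on this read-out lower numbers stand for an effect already at smaller amounts and higher numbers for an effect only at larger amounts of compound. Compound 1 `CCN(Cc1cncs1)C(=O)COc1ccc(C)cc1` gives 1100 nM, compound 2 `CCN(Cc1ccsc1)C(=O)COc1ccc(C)cc1` gives 88 nM, and compound 3 `CCCN(Cc1cccs1)C(=O)COc1ccc(C)cc1` gives 40 nM. Compound 3 therefore stands with the lowest number of the three: compound 2 lies nearest to it and compound 1 furthest away. For the measured compounds named here, the only step that can be traced to a single change is a 13-fold lower number from compound 1 to compound 2 (1.10 log units; beyond the scatter), which shows that exchanging one five-membered aromatic ring for another can move the number a great deal. Compound 2 and compound 3 differ in two places at once, so their values can only be set side by side, compound 3 giving the lower one.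

Compound 4 `Cc1ccc(OCC(=O)N(Cc2cccs2)c2ccon2)cc1` differs from compound 3 in one place: 1,2-oxazol-3-yl in place of propyl on an amide-type nitrogen. Going by the values given here, this change sits on the amide-type nitrogen, not on the saturated chain carbon where the step from compound 1 to compound 2 was made, so no measured step bears directly on it; that step only warns that bringing in a different ring can matter. With propyl giving way to 1,2-oxazol-3-yl, a moderate rise in the number is expected, a 3.8-fold higher number from compound 3 to compound 4 (0.57 log units; beyond the scatter). For compound 4 the expected value in this assay is 150 nM, in the range 30 nM to 800 nM.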

Compound 4, half-maximal effective concentration: 2 nM
Compound 4: middle estimate off by 75-fold (1.88 log units), on the high side; the measured number lies below the stated range.
By their numbers in this assay, from the lowest: compound 4; then compound 3; then compound 2; then compound 1.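

The step at the amide-type nitrogen, a 20-fold lower number from compound 3 to compound 4 (1.30 log units; beyond the scatter), shows that this position can move the number by a large amount, which the earlier step on the saturated chain carbon could not reveal. That earlier step exchanged one five-membered aromatic ring for another, whereas here propyl, which has no ring and no hydrogen-bond acceptors, gives way to 1,2-oxazol-3-yl, a five-membered aromatic ring with 2 hetero atoms and 2 hydrogen-bond acceptors, and the number falls rather than rises. No measurement available here explains why this exchange has so large an effect.

A single step cannot separate the presence of a ring on this nitrogen from the particular nitrogen and oxygen atoms of 1,2-oxazol-3-yl, so a phenyl ring or a butyl chain at the same place would be needed to tell those readings apart. On these data alone, it also remains open whether 1,2-oxazol-3-yl on this nitrogen would give a similar step when thiophen-3-yl, the group in compound 2, or 1,3-thiazol-5-yl, the group in compound 1, sits on the saturated chain carbon.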